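Changing the amide group of compound 2

The source may report more compounds than this note shows. Statements on the series, on what has been measured and on what is new or still open speak of the compounds shown alone.

compound 1 `Cc1cc(C)cc(S(=O)(=O)c2c(C(=O)NC(C)c3ccccc3O)[nH]c3ccc(Cl)cc23)c1` gives 21800 nM
compound 2 `Cc1cc(C)cc(S(=O)(=O)c2c(C(=O)NC(C)c3cccc(O)c3)[nH]c3ccc(Cl)cc23)c1` gives 16000 nM

Among the measured compounds shown here, both values come from an ADME assay on MT4 cells (Homo sapiens) for cytotoxicity, read by MTT assay (on this read-out higher numbers stand for lower toxicity in this test and lower numbers for higher toxicity in this test), and lie within the scatter of each other, so compound 2 stands level with compound 1, the only other measured compound. Compound 3 `Cc1cc(C)cc(S(=O)(=O)c2c(C(=O)NCc3ccc(CO)cc3)[nH]c3ccc(Cl)cc23)c1` keeps the shared core but carries 4-(hydroxymethyl)benzyl on the amide-type nitrogen (a group of 9 heavy atoms (8 carbon, 1 oxygen; one six-membered aromatic ring of carbon only) in place of a group of 9 heavy atoms (8 carbon, 1 oxygen; one six-membered aromatic ring of carbon only), on an amide-type nitrogen). For the measured compounds named here, the only measured step of a 1.4-fold lower number from compound 1 to compound 2 (0.13 log units; within the scatter) came from 3-hydroxyphenyl replacing 2-hydroxyphenyl. It is a different change and only a weak guide, but no step beyond the scatter is expected in this assay for compound 3. Compound 3 is estimated at 18000 nM with an expected range from 8000 nM to 40000 nM in this test. This estimate means a 1.1-fold higher number from compound 2 to compound 3 (0.05 log units; within the scatter) as the expected step.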

Compound 3, half-maximal cytotoxic concentration: 31100 nM
The estimate for compound 3 lay 1.7-fold (0.24 log units) below the measured number; low and high end bracket the measured number.
By their numbers in this assay, from the lowest: compounds 2, 1 and 3 (each within the scatter of the next).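

In this assay, 4-(hydroxymethyl)benzyl on the amide-type nitrogen gives a 1.9-fold higher number from compound 2 to compound 3 (0.29 log units; within the scatter) and a 1.4-fold higher number from compound 1 to compound 3 (0.15 log units; within the scatter) as its two steps. Among the compounds shown here, the earlier pair showed only that a hydroxyl group could sit at a different place on the ring, whereas compound 3 also has a different chain joining the ring to the nitrogen. Even so, all three compounds remain within the scatter of one another.

Still open, going by these compounds, is whether an amine or a carboxylic acid in place of the hydroxyl, or a longer chain, would give a step beyond the scatter. Nothing available explains these numbers.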